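The source may hold more compounds than are shown below. What is called first, only, known or untested is meant among the compounds shown, and "the series" means these compounds.

In an assay on cell membranes for binding affinity to 2-oxoglutarate receptor 1 (Rattus norvegicus), read by radioligand binding (on this read-out higher numbers stand for weaker inhibition and lower numbers for stronger inhibition), compound 1 `CCC(C)NC(=O)[C@H]1OC(n2cnc3c(N)ncnc32)[C@H](O)[C@@H]1O` gives 198 nM, the highest number among the three compounds measured in this assay. Compound 2 `CC(=O)NCCCCCCCCNC(=O)[C@H]1OC(n2cnc3c(N)ncnc32)[C@H](O)[C@@H]1O` gives 10 nM in this assay, and compound 3 `C[C@H]1CC[C@H](NC(=O)[C@H]2O[C@@H](n3cnc4c(N)ncnc43)[C@H](O)[C@@H]2O)CC1` gives 12.9 nM; both of these lie beyond the scatter from compound 1, so compound 1 is the weakest of the three. Compound 4 `CCONC(=O)[C@H]1OC(n2cnc3c(N)ncnc32)[C@H](O)[C@@H]1O` differs from compound 1 by ethoxy in place of sec-butyl on an amide-type nitrogen. For the measured compounds named here, no measured pair shows this kind of change, so the size of its effect is unknown from the data. The step from compound 1 to compound 4 is expected to be small, a 2.0-fold higher number from compound 1 to compound 4 (0.31 log units; beyond the scatter), leaning toward a higher number. Compound 4 is therefore estimated at 400 nM in this assay, within a range of 100 nM to 2000 nM.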

Compound 4, inhibition constant: 67 nM
Estimate against measurement, compound 4: 6.0-fold (0.78 log units) above, outside the stated range (below it).
By their numbers in this assay, from the lowest: compounds 2 and 3 (each within the scatter of the next); then compound 4; then compound 1.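

For the compounds shown here, the change from sec-butyl to ethoxy on an amide-type nitrogen gives a 3.0-fold lower number from compound 1 to compound 4 (0.47 log units; beyond the scatter) in this assay and is the first step that can be read at this place. It shows that this nitrogen can carry a group with an oxygen directly attached and one heavy atom fewer, with stronger inhibition rather than a loss. Nothing measured here explains the step.

Going by these compounds, it remains open whether the oxygen or the shorter chain accounts for the change. An ethylamino group or a methoxyamino group at this place would help separate the two.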